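The source may hold more compounds than are shown below. What is called first, only, known or untested is meant among the compounds shown, and "the series" means these compounds.

Measured in an ADME assay on RAW264.7 cells (Mus musculus) for cytotoxicity, read by trypan blue exclusion, with a stated time of 48 h; on this read-out lower numbers stand for stronger inhibition of growth and higher numbers for weaker inhibition of growth:
compound 1 `Cc1c(CNCc2ccccc2)cc(-c2ccc(Cl)cc2)n1-c1ccc(Cl)cc1`: "not determined" (no result reported)
compound 2 `Cc1cc(CNC2CCCCC2)c(C)n1-c1ccc(Cl)cc1`: 10 ug/mL
compound 3 `Cc1cc(CNOCc2ccccc2)c(C)n1-c1ccc(Cl)cc1`: 133 ug/mL

In this assay compound 3, at 133 ug/mL, holds the higher of the two numbers available, since compound 1 has no result to compare. Still unmeasured is compound 4 `Cc1cc(CNCc2ccccc2)c(C)n1-c1ccc(Cl)cc1`, whose structure differs from that of compound 3 as follows: benzyl in place of benzyloxy on an amine nitrogen. Within the data shown here, only one measured step bears on this change: a 13-fold higher number from compound 2 to compound 3 (1.12 log units; beyond the scatter). That large step, beyond the scatter, brought in benzyloxy in place of cyclohexyl on an amine nitrogen. The new change removes benzyloxy from that place, so a sizeable move toward a lower number is expected, probably not a full return, as benzyl is not cyclohexyl and a single step is thin evidence. Compound 1 also carries benzyl on an amine nitrogen but offers no number. The expected change is a 6.7-fold lower number from compound 3 to compound 4 (0.82 log units; beyond the scatter). Compound 4 is estimated at 20 ug/mL, with an expected range from 6 ug/mL to 70 ug/mL.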

Compound 4, concentration for 50% growth inhibition: 5.5 ug/mL
The estimate for compound 4 lay 3.6-fold (0.56 log units) above the measured number; measured number below the stated range.
By their numbers in this assay, from the lowest: compounds 4 and 2 (each within the scatter of the next); then compound 3.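

In this assay, benzyl in place of benzyloxy on an amine nitrogen gave a 24-fold lower number from compound 3 to compound 4 (1.38 log units; beyond the scatter) and so the high number of compound 3 now stands apart from both of the other two groups at this place, not only from cyclohexyl. The exchange of cyclohexyl for benzyl gave a 1.8-fold lower number from compound 2 to compound 4 (0.26 log units; within the scatter) and thus shows that an aromatic ring and a saturated ring on this nitrogen cannot be told apart in this read-out. No measurement is available that explains the behaviour of benzyloxy.

From the compounds shown here alone, whether a longer chain, a phenethyl group or a carboxylic acid at this place would stay with benzyl and cyclohexyl or move toward benzyloxy remains open. Going by these compounds, how benzyl behaves on a different core also remains open: compound 1 carries it, but has no reported result.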